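Piperazine replaced by triazole ester on the shared core

The source may report more compounds than this note shows. Statements on the series, on what has been measured and on what is new or still open speak of the compounds shown alone.

Three compounds of the series carry a common core and differ only on the amine nitrogen of a six-membered ring. Compound 1 `CN1CCN(Cc2nnc(-c3cc(S(N)(=O)=O)c(SCc4ccccc4)cc3Cl)o2)CC1` gives 75000 nM in a functional assay on MCF7 cells (Homo sapiens) for cytotoxicity, read by MTT assay, with a stated time of 72 h (on this read-out higher numbers stand for weaker inhibition and lower numbers for stronger inhibition), and stands second highest of the three, nearest to compound 3 `Cc1ccc(C)c(N2CCN(Cc3nnc(-c4cc(S(N)(=O)=O)c(SCc5ccccc5)cc4Cl)o3)CC2)c1` with 51000 nM and furthest from compound 2 `NS(=O)(=O)c1cc(-c2nnc(CN3CCN(c4ccc(Cl)cc4)CC3)o2)c(Cl)cc1SCc1ccccc1` with 280000 nM. The steps are modest: a 3.7-fold higher number from compound 1 to compound 2 (0.57 log units; beyond the scatter) and a 5.5-fold lower number from compound 2 to compound 3 (0.74 log units; beyond the scatter) lie beyond the scatter, whereas a 1.5-fold lower number from compound 1 to compound 3 (0.17 log units; within the scatter) does not.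

Compound 4 `CCOC(=O)c1cn(Cc2nnc(-c3cc(S(N)(=O)=O)c(SCc4ccccc4)cc3Cl)o2)nn1` is unmeasured. Relative to compound 1 the change is 4-(ethoxycarbonyl)-1H-1,2,3-triazol-1-yl in place of 4-methylpiperazin-1-yl on a saturated chain carbon bound to an aromatic carbon. Among the measured compounds shown here, no measured step exchanges the ring itself; the three known steps vary only the group on its nitrogen, so they bear on the new compound only as a rough gauge of how much this part of the molecule moves the number. On that basis the step from compound 1 to compound 4 is expected to be small in this assay, with no clear direction, a 1.1-fold higher number from compound 1 to compound 4 (0.05 log units; within the scatter). For compound 4 the estimate in this assay is 85000 nM, within 25000 nM to 300000 nM.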

Compound 4, half-maximal inhibitory concentration: 150000 nM
For compound 4 the middle estimate is 1.8-fold (0.25 log units) below the measured one; the measured number falls inside the stated range.
By their numbers in this assay, from the lowest: compounds 3, 1, 4 and 2 (each within the scatter of the next, the first and the last beyond it).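

Exchanging the whole ring, not just the group on its nitrogen, is tolerated on the saturated chain carbon: in this assay the step of a 2.0-fold higher number from compound 1 to compound 4 (0.30 log units; within the scatter) stays small even though 4-(ethoxycarbonyl)-1H-1,2,3-triazol-1-yl shares neither ring size nor ring type with 4-methylpiperazin-1-yl. Among the compounds shown here, a number of this order therefore does not depend on the piperazine ring, and the earlier compounds, which all keep that ring, could not show this. The series holds no measurement that would explain this reading.

On these data alone, it remains open whether the ethoxycarbonyl group contributes anything, which a carboxylic acid or a primary amide on the same triazole would test. An open-chain amine such as dimethylamino in place of the ring would show whether any ring is needed here.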